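The compounds below may be only part of what the source reports. "The series", "measured", "known", "first", "only" and "open" are said of these compounds alone.

Measured compounds:
Compound 1, `CCn1ncc(-c2nc3c(N[C@H]4CCN(C(=O)C5CCOCC5)C4)ncnc3n2C)c1C`: 95 mL/min/kg
Compound 2, `CCn1ncc(-c2nc3c(N4CCC(n5c(=O)[nH]c6ncccc65)CC4)ncnc3n2C)c1C`: 5.8 mL/min/kg
Compound 3, `CCn1ncc(-c2nc3c(O[C@H]4CCN(C(=O)C5CC5)C4)ncnc3n2C)c1C`: 23 mL/min/kg

In an ADME assay on the whole organism (Rattus norvegicus, strain Wistar Han) for pharmacokinetics (on this read-out lower numbers stand for slow clearance and higher numbers for fast clearance), compound 3 stands second highest of the three numbers. Its nearest neighbour is compound 2, whose value is a good deal lower, and its furthest is compound 1, whose value is a good deal higher; both of those gaps lie beyond the usual scatter of the measurement. No single-point change links any two of the measured compounds, so nothing can be said about what any one alteration does on its own.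

Compound 4, `CCn1ncc(-c2nc3c(O[C@H]4CCN(C(=O)C5CCOCC5)C4)ncnc3n2C)c1C`, has not yet been measured. It differs from compound 3 in one place: oxan-4-yl in place of cyclopropyl on a carbonyl carbon. The group that enters is the same one that compound 1 carries on its carbonyl carbon, though compound 1 also differs from compound 3 elsewhere. The value of compound 1, 95 mL/min/kg, therefore cannot be read as the effect of this group alone.

Among the measured compounds shown here, with no measured step to lean on, only a modest change in this assay is expected for compound 4, most likely toward a slightly higher number, as a 1.3-fold higher number from compound 3 to compound 4 (0.12 log units; within the scatter). Compound 4 is therefore estimated at 30 mL/min/kg, with a plausible range from 12 mL/min/kg to 75 mL/min/kg.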

Compound 4, clearance in the Rattus norvegicus assay: 41 mL/min/kg
For compound 4 the middle estimate is 1.4-fold (0.14 log units) below the measured one, within the range that was stated.
By their numbers in the Rattus norvegicus assay, from the lowest: compound 2; then compounds 3 and 4 (each within the scatter of the next); then compound 1.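

Among the compounds shown here, the swap of cyclopropyl for oxan-4-yl on this carbonyl carbon can now be read on its own, which no earlier pair of compounds allowed: in the Rattus norvegicus assay it gives a 1.8-fold higher number from compound 3 to compound 4 (0.25 log units; within the scatter), so a ring with more heavy atoms and a hydrogen-bond acceptor leaves clearance indistinguishable from that of the smaller ring. In a physicochemical assay for lipophilicity (on this read-out lower numbers stand for lower lipophilicity and higher numbers for higher lipophilicity), compound 3 gives 1.2 and compound 4 gives 1.1, so the same swap also leaves the two compounds within the scatter of each other for lipophilicity. Nothing among the data shown explains why this step is so small.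

From the compounds shown here alone, it remains open how a different kind of group on this carbonyl carbon, such as a simple amine or a longer carbon chain, would behave in the Rattus norvegicus assay. A single pair also cannot show whether oxan-4-yl in place of cyclopropyl would give an equally small step on a different core, so this result should not yet be taken as a general rule.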